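This account rests on a few compounds, and the source may have more. Where it says the series, first, only, none or still open, it means among the compounds named here.

Working notes on the series. In a functional assay on A549 cells (Homo sapiens) for cytotoxicity, read by MTT assay, with a stated time of 72 h (on this read-out higher numbers stand for weaker inhibition and lower numbers for stronger inhibition), compound 1 `COc1ccc(/C=N/NC(=O)Nc2ccc(Oc3ccnc(-c4nncn4CCN(C)C)c3)c(F)c2)c(OC)c1` gives 2820 nM. Compound 2 `CN(C)CCn1cnnc1-c1cc(Oc2ccc(NC(=O)N/N=C/c3ccccc3O[N+](=O)[O-])cc2F)ccn1` gives 1200 nM in this assay. Compound 3 `COc1cc(/C=N/NC(=O)Nc2ccc(Oc3ccnc(-c4nncn4CCN(C)C)c3)c(F)c2)cc(OC)c1OC` reaches only the limit of this assay, > 100000 nM, so for compound 3 a limit and not a number is known; see (the limit of > 100000 nM in this assay, at which 1 of the 3 values shown sits). Among the measured steps, a 2.4-fold lower number from compound 1 to compound 2 (0.37 log units; beyond the scatter). Against that, an at least 35-fold higher number from compound 1 to compound 3 (1.54 log units; beyond the scatter) and an at least 83-fold higher number from compound 2 to compound 3 (1.92 log units; beyond the scatter). On the numbers shown compound 3 is thus the weakest of the three, beyond the scatter from both compound 1 and compound 2, with no number of its own.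

Compound 4 `CN(C)CCn1cnnc1-c1cc(Oc2ccc(NC(=O)N/N=C/c3ccc(Cl)cc3)cc2F)ccn1` is not yet measured. The change: 4-chlorophenyl in place of 3,4,5-trimethoxyphenyl on a carbon with a double bond to nitrogen. Among the measured compounds shown here, the steps that bear on it are the two leading into compound 3, an at least 35-fold higher number from compound 1 to compound 3 (1.54 log units; beyond the scatter) and an at least 83-fold higher number from compound 2 to compound 3 (1.92 log units; beyond the scatter), both large and both rising as the 3,4,5-trimethoxyphenyl enters. Compound 4 takes the reverse direction, removing that group for 4-chlorophenyl, a smaller aryl closer in kind to those in compound 1 and compound 2. A large downward step is therefore expected, an at least 40-fold lower number from compound 3 to compound 4 (1.60 log units; beyond the scatter) in this assay, though its size is uncertain since compound 3 carries only a limit. Compound 4 is expected to give about 2500 nM in this assay, within 800 nM to 15000 nM.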

Compound 4, half-maximal inhibitory concentration: 780 nM
For compound 4 the middle estimate is 3.2-fold (0.51 log units) above the measured one; measured number below the stated range.
By their numbers in this assay, from the lowest: compounds 4 and 2 (each within the scatter of the next); then compound 1. At a limit, above all of these: compound 3.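

In this assay, at the carbon with a double bond to nitrogen, 4-chlorophenyl, with 0 hydrogen-bond acceptors, does not separate from 2-(nitrooxy)phenyl, a 1.5-fold lower number from compound 2 to compound 4 (0.19 log units; within the scatter), and goes beyond 2,4-dimethoxyphenyl, a 3.6-fold lower number from compound 1 to compound 4 (0.56 log units; beyond the scatter). An oxygen-bearing substituent on this aryl is therefore not required for a value in this range, while 3,4,5-trimethoxyphenyl remains the one aryl of the four that falls away, an at least 120-fold lower number from compound 3 to compound 4 (2.10 log units; beyond the scatter). That step gives only a bound, since the value for compound 3 is a limit and not a number: the limit of > 100000 nM in this assay, at which 1 of the 4 values shown sits.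

From the compounds shown here alone, whether the chlorine itself contributes remains open, and a plain phenyl, a 4-fluorophenyl or an aryl carrying an amine or a carboxylic acid at this place would test that. Also open, going by these compounds, is whether the loss with 3,4,5-trimethoxyphenyl belongs to the three methoxy groups together or to one of them, a question that a 3,4-dimethoxyphenyl or a 3,5-dimethoxyphenyl would address.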